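Adding a Second Methoxy Group to a Pyrazoline Series

The source may hold more compounds than are shown below. What is called first, only, known or untested is meant among the compounds shown, and "the series" means these compounds.

Among the measured compounds shown here, compound 2 `COc1ccc(C2CC(c3ccccc3)=NN2C2=NC(=O)/C(=C3\C(=O)Nc4ccc(Br)cc43)S2)cc1` is one of two compounds measured so far in a functional assay on cells (Cancer cell lines, Homo sapiens) for cytotoxicity, read by sulforhodamine B assay, with a stated time of 48 h; on this read-out lower numbers stand for stronger inhibition of growth and higher numbers for weaker inhibition of growth. In this assay, for the measured compounds named here, compound 2 gives 200 nM, the lower of the two numbers, though its only neighbour, compound 1 `O=C1N=C(N2N=C(c3ccccc3)CC2c2ccccc2O)S/C1=C1/C(=O)Nc2ccc(Br)cc21`, lies within the scatter of it; in this assay compound 1 gives 240 nM. Going by the values given here, the single measured step is a 1.2-fold lower number from compound 1 to compound 2 (0.08 log units; within the scatter), a change of 4-methoxyphenyl in place of 2-hydroxyphenyl on a saturated ring carbon that moved the number by less than the usual scatter.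

Compound 3 `COc1ccc(C2=NN(C3=NC(=O)/C(=C4\C(=O)Nc5ccc(Br)cc54)S3)C(c3ccc(OC)cc3)C2)cc1` has not yet been measured. It differs from compound 2 by methoxy in place of hydrogen on an aromatic carbon, on an aromatic carbon of a six-membered aromatic ring of carbon only, para to a large group; cut one bond further out, the change reads phenyl to 4-methoxyphenyl. Among the compounds with values here, the only step that bears on it, the addition of a methoxy-bearing ring from compound 1 to compound 2, was within the scatter, so no shift beyond the scatter is expected in this assay.

Compound 3 is therefore expected to give about 220 nM in this assay, between 100 nM and 500 nM, a step of a 1.1-fold higher number from compound 2 to compound 3 (0.04 log units; within the scatter).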

Compound 3, concentration for 50% growth inhibition: 200 nM
For compound 3 the middle estimate is 1.1-fold (0.04 log units) above the measured one, within the range that was stated.
By their numbers in this assay, from the lowest: compounds 2, 3 and 1 (each within the scatter of the next).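

In this assay the phenyl ring of compound 2 takes on a methoxy group, on an aromatic carbon para to a large group, and the step is no change at the digits printed from compound 2 to compound 3 (within the scatter). Among the compounds shown here, the earlier step concerned a group on a saturated ring carbon, so this is the first reading for this other ring, and here the change from phenyl to 4-methoxyphenyl, which adds 2 heavy atoms and 1 hydrogen-bond acceptor, leaves the number in place, showing that this position accepts a methoxy group without a shift beyond the scatter in this assay. Nothing at hand explains why the number holds steady at this position.

From the compounds shown here alone, a single methoxy group says little about other groups at this place: whether an amine, a carboxylic acid or a longer chain such as butoxy would also stay within the scatter remains open. Also open, going by these compounds, is whether a small atom such as fluorine or chlorine on this same carbon would leave the number just as steady.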